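A Methoxy Group Added to the Phenyl Ring

The source may report more compounds than this note shows. Statements on the series, on what has been measured and on what is new or still open speak of the compounds shown alone.

Measured so far:
compound 1 `CCc1nnc2sc(-c3c[nH]nc3-c3ccccc3)nn12`: 29.4%
compound 2 `CCCc1nnc2sc(-c3c[nH]nc3-c3ccccc3)nn12`: 56.9%

In a functional assay on the whole organism (strain Wistar) for inhibition, with Rattus norvegicus as the target, read by paw edema, with stated times of 30 min and 2.5 h, at a dose of 20 mg/kg by the intraperitoneal route (on this read-out higher numbers stand for more inhibition at the one dose given (going by the name of the read-out) and lower numbers for less inhibition), compound 1 gives 29.4% and compound 2 gives 56.9%. Going by the values given here, compound 2 thus stands highest of the two numbers, its only neighbour being compound 1. Among the compounds with values here, the single measured step, a number 27.5 percentage points higher from compound 1 to compound 2 (beyond the scatter), concerns the saturated chain and not the phenyl ring. Compound 3 `CCCc1nnc2sc(-c3c[nH]nc3-c3ccc(OC)cc3)nn12` differs from compound 2 by methoxy in place of hydrogen on an aromatic carbon. Within the data shown here, no measured step touches that ring, so in this assay the expected step of a number 1.9 percentage points lower from compound 2 to compound 3 (within the scatter) is within the scatter. Compound 3 is therefore estimated at 55%, with a range from 35% to 72%.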

Compound 3, a percentage reported as inhibition, in the whole organism at one dose (the size of the read-out at that dose, not a potency): 13.5%
The estimate for compound 3 lay 41.5 percentage points above the measured number; measured number outside the range, below it.
By their numbers in this assay, from the lowest: compound 3; then compound 1; then compound 2.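

Going by these compounds alone, the phenyl ring, which no earlier step had touched, proves sensitive in this assay: phenyl to 4-methoxyphenyl gives a number 43.4 percentage points lower from compound 2 to compound 3 (beyond the scatter). A single methoxy on an aromatic carbon, para to a large group, is thus enough to remove most of the inhibition seen with compound 2. No available evidence accounts for this fall.

The compounds shown leave open whether the loss is specific to methoxy or would also follow from a fluorine or a hydroxyl at that carbon. They also leave open whether the same change would cost as much on the chain of compound 1.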